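The source may hold more compounds than are shown below. What is called first, only, known or untested is meant among the compounds shown, and "the series" means these compounds.

Values in an ADME assay on HT-29 cells (Homo sapiens) for cytotoxicity, read by MTT assay, with a stated time of 72 h; a higher number here means a weaker inhibitor, a lower number a stronger inhibitor:
- compound 1 `COc1ccc(C2=C(c3cc(OC)c(OC)c(OC)c3)C(=O)C(OC(C)=O)C2)cc1OC(C)C`: > 100 ug/mL
- compound 2 `COc1ccc(C2=C(c3cc(OC)c(OC)c(OC)c3)C(=O)CC2O[SiH2]C(C)(C)C)cc1`: > 100 ug/mL
- compound 3 `COc1ccc(C2=C(c3cc(OC)c(OC)c(OC)c3)C(=O)C(O)C2)cc1`: < 1 ug/mL

All three values are limits of the assay and not numbers. Compound 2 sits at the limit of > 100 ug/mL in this assay, at which 2 of the 3 values shown sit, and compound 1 shares that limit. Compound 3 alone sits at the limit of < 1 ug/mL in this assay, at which 1 of the 3 values shown sits.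

Compound 4 `COc1ccc(OC)c(C2=C(c3cc(OC)c(OC)c(OC)c3)C(=O)CC2O[SiH2]C(C)(C)C)c1` has not yet been measured. It differs from compound 2 in one place, with 2,5-dimethoxyphenyl in place of 4-methoxyphenyl on a double-bonded ring carbon.

Within the data shown here, no measured pair of compounds shows this change, so the data give no size for it. The expectation therefore rests on compound 2 alone, whose reading of > 100 ug/mL is a limit. No step beyond the usual scatter is expected in this assay, and neither direction is favoured. The expected step is a number no higher from compound 2 to compound 4 (the limit leaves the size open). For compound 4 the estimate is 100 ug/mL, with an expected range of 40 ug/mL to 250 ug/mL. The assay may well report only a limit again.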

Compound 4, half-maximal inhibitory concentration: 5 ug/mL
Compound 4: the middle estimate sits 20-fold (1.30 log units) above what was measured, outside the stated range (below it).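

In this assay, the aromatic group on this double-bonded ring carbon proves able to change the reading on its own: 2,5-dimethoxyphenyl in place of 4-methoxyphenyl gives an at least 20-fold lower number from compound 2 to compound 4 (1.30 log units; beyond the scatter). The earlier compounds shown here differ from one another in more than one place, so they could not tie a change in the reading to any single group. The full size of this step stays unknown because the reading of compound 2 is a limit of the assay and not a number: the limit of > 100 ug/mL in this assay, at which 2 of the 4 values shown sit.

The compounds shown do not tell whether both methoxy groups of 2,5-dimethoxyphenyl are needed for this step, or how an amine or a carboxylic acid on that ring would read. They also leave open whether the same change would have a similar effect on the core of compound 3.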